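A few compounds are considered here, and "the series" means these few. Any claim that something is new, unique, unknown or untested is made for them only; others in the source may bear on it.

Measured compounds:
- compound 1, `Brc1cn2ccnc2c(-c2ccc3ncn(C4CCCCC4)c3c2)n1`: 10.2%
- compound 2, `c1cn2cc(-c3ccsc3)nc(-c3ccc4ncn(C5CCCCC5)c4c3)c2n1`: 10%
- compound 3, `CC(=O)c1ccc(-c2cn3ccnc3c(-c3ccc4ncn(C5CCCCC5)c4c3)n2)cc1`: 8.6%

In a functional assay on NCI-H23 cells (Homo sapiens) for inhibition, read by sulforhodamine B assay, with a stated time of 48 h, tested at 10 uM (a higher number here means more inhibition at the concentration tested (going by the name of the read-out), a lower number less inhibition), compound 1 is the reference point, and the steps of a number 0.2 percentage points lower from compound 1 to compound 2 (within the scatter) and a number 1.6 percentage points lower from compound 1 to compound 3 (within the scatter) both lie within the scatter, so none of the three compounds stands apart from the others. Compound 4, `Brc1ccc(-c2cn3ccnc3c(-c3ccc4ncn(C5CCCCC5)c4c3)n2)cc1`, differs from compound 1 in one place: 4-bromophenyl in place of bromo on an aromatic carbon. For the measured compounds named here, the steps that bear on this are those where bromo was replaced by a ring, a number 0.2 percentage points lower from compound 1 to compound 2 (within the scatter) and a number 1.6 percentage points lower from compound 1 to compound 3 (within the scatter), and both stayed within the scatter. A step of the same kind is therefore expected here, a number 0.7 percentage points lower from compound 1 to compound 4 (within the scatter), with no change beyond the scatter. Compound 4 is estimated at 9.5%, within a range from 2% to 18%.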

Compound 4, a percentage reported as inhibition, at one concentration (the size of the read-out at that concentration, not a potency): 8.38%
Compound 4: the middle estimate sits 1.1 percentage points above what was measured; measured number inside the range.
By their numbers in this assay, from the lowest: compounds 4, 3, 2 and 1 (each within the scatter of the next).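

In this assay, a third ring put in place of bromo, 4-bromophenyl, again leaves the read-out within the scatter (a number 1.8 percentage points lower from compound 1 to compound 4 (within the scatter)). Bromo in place of acetyl on the outer phenyl ring (a number 0.2 percentage points lower from compound 3 to compound 4 (within the scatter)) and 4-bromophenyl in place of thiophen-3-yl (a number 1.6 percentage points lower from compound 2 to compound 4 (within the scatter)) also stay within it, so this read-out does not separate the ring groups shown at this position. No supporting measurement bears on this result. On these data alone, whether an amine, a carboxylic acid or a longer chain here would move the number beyond the scatter remains open.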